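Moving the halogen on the benzyl ether: from compound 3 to compound 4

This account rests on a few compounds, and the source may have more. Where it says the series, first, only, none or still open, it means among the compounds named here.

Three compounds share one core and differ only in the halogen on the outer benzyl ring. Compound 1 `Cc1cc(C(=O)O)nn1Cc1cc(Br)ccc1OCc1ccccc1`, with no halogen there, gives 15.1 nM in a functional assay on CHO-K1 cells for antagonist activity at prostaglandin E2 receptor EP1 subtype (Homo sapiens), read by FLIPR; a higher number here means a weaker inhibitor, a lower number a stronger inhibitor. Compound 2 `Cc1cc(C(=O)O)nn1Cc1cc(Br)ccc1OCc1ccc(Cl)cc1` gives 8.71 nM, and compound 3 `Cc1cc(C(=O)O)nn1Cc1cc(Br)ccc1OCc1ccc(F)cc1` gives 11.8 nM, the second highest of the three numbers; its neighbours differ from it only within the scatter, a 1.3-fold lower number from compound 1 to compound 3 (0.11 log units; within the scatter) and a 1.4-fold higher number from compound 2 to compound 3 (0.13 log units; within the scatter), and a 1.7-fold lower number from compound 1 to compound 2 (0.24 log units; within the scatter) is likewise small. Compound 4 `Cc1cc(C(=O)O)nn1Cc1cc(Br)ccc1OCc1ccccc1Cl` carries 2-chlorophenyl in place of 4-fluorophenyl on a saturated chain carbon bound to an oxygen on an aromatic ring. Since every measured halogen change stayed inside the scatter, the expected step of a 1.1-fold lower number from compound 3 to compound 4 (0.03 log units; within the scatter) is also none beyond it. Compound 4 is therefore estimated at 11 nM, between 4 nM and 30 nM.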

Compound 4, inhibition constant: 28.8 nM
Beside the measured number, compound 4's estimate is 2.6-fold (0.42 log units) below it, within the range that was stated.
By their numbers in this assay, from the lowest: compounds 2, 3, 1 and 4 (each within the scatter of the next, the first and the last beyond it).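

On the outer benzyl ring, the place of the chlorine matters, which the earlier halogen swaps could not show: 2-chlorophenyl in place of 4-chlorophenyl gives a 3.3-fold higher number from compound 2 to compound 4 (0.52 log units; beyond the scatter), a step beyond the scatter. The change from 4-fluorophenyl gives a 2.4-fold higher number from compound 3 to compound 4 (0.39 log units; beyond the scatter), also beyond it, while the comparison with the plain phenyl ring gives a 1.9-fold higher number from compound 1 to compound 4 (0.28 log units; within the scatter), which stays within it. Nothing measured here explains these differences. Going by these compounds, whether a methoxy or trifluoromethyl group on this ring would follow the chloro group remains open.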